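The source may report more compounds than this note shows. Statements on the series, on what has been measured and on what is new or still open speak of the compounds shown alone.

Compound 1 `Nc1nc(N)c2c(-c3ccsc3)cn([C@@H]3O[C@H](CO)[C@@H](O)[C@H]3O)c2n1` is tested in a functional assay on HeLa S3 cells (Homo sapiens) for antiproliferative activity, read by XTT assay, with a stated time of 72 h; on this read-out higher numbers stand for weaker inhibition and lower numbers for stronger inhibition. In this assay compound 1 gives only a limit of the assay, > 20000 nM. Compound 2 `Cc1nc(N)c2c(-c3ccsc3)cn([C@@H]3O[C@H](CO)[C@@H](O)[C@H]3O)c2n1` likewise gives only a limit of the assay, > 20000 nM. The step that the two limits leave unreadable from compound 1 to compound 2 cannot be read because of the limit of > 20000 nM in this assay, at which 2 of the 2 values shown sit. Compound 3 `Nc1nc(N)c2c(-c3cccs3)cn([C@@H]3O[C@H](CO)[C@@H](O)[C@H]3O)c2n1` differs from compound 1 by thiophen-2-yl in place of thiophen-3-yl on an aromatic carbon. Within the data shown here, no measured step bears on this change, and compound 1 itself stands only at a limit, so no size or direction beyond the scatter can be foreseen. Compound 3 is therefore estimated at 20000 nM, between 5000 nM and 60000 nM. The expected step is a number no higher from compound 1 to compound 3 (the limit leaves the size open), most likely again read only as a limit.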

Compound 3, half-maximal inhibitory concentration: > 20000 nM
Compound 3: a limit, no number; the forecaster's own chance of this, stated with the estimate: 85%; the middle value lies on the limit itself.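

Compound 1 and compound 3 both sit at a limit, so no step between them can be read: the limit of > 20000 nM in this assay, at which 3 of the 3 values shown sit.

From the compounds shown here alone, whether thiophen-2-yl and thiophen-3-yl, or methyl and amino, differ at all in this assay stays open.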